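Moving the Methyl Group: Compound 2 to Compound 3

A few compounds are considered here, and "the series" means these few. Any claim that something is new, unique, unknown or untested is made for them only; others in the source may bear on it.

For the measured compounds named here, in a functional assay on CHO cells for antagonist activity at prostaglandin D2 receptor (Mus musculus), read by cAMP accumulation (a lower number here means a stronger inhibitor, a higher number a weaker inhibitor), compound 2 `Cc1cc(CC(=O)O)cc(NC(=O)c2ccc(OC[C@@H]3CN(C)c4ccccc4O3)cc2Cl)c1` gives 5.4 nM, the lowest of the two numbers measured so far. Going by the values given here, its nearest neighbour, compound 1 `CN1C[C@@H](COc2ccc(C(=O)Nc3cccc(CC(=O)O)c3)c(Cl)c2)Oc2ccccc21`, gives 20 nM, and the step of a 3.7-fold lower number from compound 1 to compound 2 (0.57 log units; beyond the scatter) is the only measured change here, methyl in place of hydrogen on an aromatic carbon. Compound 3 `Cc1ccc(NC(=O)c2ccc(OC[C@@H]3CN(C)c4ccccc4O3)cc2Cl)cc1CC(=O)O` keeps the same atoms but joins them differently: 3-(carboxymethyl)-4-methylphenyl in place of 3-(carboxymethyl)-5-methylphenyl on an amide-type nitrogen. Among the compounds with values here, no measured step covers this rearrangement; the one measured step shows that adding the methyl helped, but says nothing about where on the ring it sits. The expectation is therefore a step of a 1.7-fold higher number from compound 2 to compound 3 (0.22 log units; within the scatter) no larger than the scatter, with a wide range to allow for either direction. Compound 3 is estimated at 9 nM in this assay, expected to fall between 3 nM and 30 nM.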

Compound 3, half-maximal inhibitory concentration: 3.9 nM
Beside the measured number, compound 3's estimate is 2.3-fold (0.36 log units) above it; low and high end bracket the measured number.
By their numbers in this assay, from the lowest: compounds 3 and 2 (each within the scatter of the next); then compound 1.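

The two placements of the methyl group, 3-(carboxymethyl)-5-methylphenyl and 3-(carboxymethyl)-4-methylphenyl, cannot be told apart in this assay, with a 1.4-fold lower number from compound 2 to compound 3 (0.14 log units; within the scatter) as the result. The benefit of adding a methyl is therefore not tied to a single place on this ring, since the new placement also improves on the compound without the methyl, with a 5.1-fold lower number from compound 1 to compound 3 (0.71 log units; beyond the scatter) beyond the scatter. No measurement available here explains why these two placements perform alike.

Still open, from the compounds shown here alone, is whether the methyl would be tolerated at the remaining places on the ring. Going by these compounds, it is also open whether a larger ethyl group, a methoxy group or a chlorine atom would match the methyl at either of these two places.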